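The source may hold more compounds than are shown below. What is called first, only, known or untested is meant among the compounds shown, and "the series" means these compounds.

Of the compounds shown here, two built on one shared core have been tested in a functional assay on MDA-MB-231 cells (Homo sapiens) for inhibition, read by sulforhodamine B assay, with a stated time of 48 h, tested at 10 uM; on this read-out higher numbers stand for more inhibition at the one concentration tested (going by the name of the read-out) and lower numbers for less inhibition. Compound 1 `COc1ccc(-c2cn3ccnc3c(-c3ccc4ncn(C5CCCCC5)c4c3)n2)cc1` gives 71.1% in this assay. Compound 2 `c1cn2cc(-c3ccsc3)nc(-c3ccc4ncn(C5CCCCC5)c4c3)c2n1` gives 1.35% in this assay, which places it lowest of the two numbers shown. For the measured compounds named here, the single measured step, a number 69.8 percentage points lower from compound 1 to compound 2 (beyond the scatter), is the only change recorded so far, and it replaces a whole group rather than moving a ring's point of attachment.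

Compound 3 `c1csc(-c2cn3ccnc3c(-c3ccc4ncn(C5CCCCC5)c4c3)n2)c1` differs from compound 2 by thiophen-2-yl in place of thiophen-3-yl on an aromatic carbon. Going by the values given here, no measured step swaps one thiophene attachment for the other, so the recorded step bears on it only indirectly, by showing that compound 2 already sits near the bottom of the scale. A move beyond the scatter is not expected, though a modest rise remains possible. Compound 3 is therefore estimated at 8% in this assay, with a range from 0% to 30%. The expected step is a number 6.7 percentage points higher from compound 2 to compound 3 (within the scatter), within the scatter.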

Compound 3, a percentage reported as inhibition, at one concentration (the size of the read-out at that concentration, not a potency): 10.8%
The estimate for compound 3 lay 2.8 percentage points below the measured number; the range from low to high includes it.
By their numbers in this assay, from the lowest: compounds 2 and 3 (each within the scatter of the next); then compound 1.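

In this assay, putting thiophen-2-yl in place of thiophen-3-yl at this position gives a number 9.5 percentage points higher from compound 2 to compound 3 (within the scatter) and so shows that the point of attachment of the thiophene ring makes no clear difference here. The large drop from the 4-methoxyphenyl compound therefore holds for both thiophene attachments, with thiophen-2-yl giving a number 60.3 percentage points lower from compound 1 to compound 3 (beyond the scatter) and thus a loss on the same broad scale as the earlier step. No supporting evidence is available to explain this difference between the thiophene rings and 4-methoxyphenyl.

The compounds shown leave open whether the inhibition depends on the methoxy group or on the benzene ring that carries it, a question that plain phenyl could help to settle. They also leave open how an amine or a carboxylic acid in place of that methoxy group would read out.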